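A Second Chloro Added to an Already Weak Compound

The source may hold more compounds than are shown below. What is called first, only, known or untested is meant among the compounds shown, and "the series" means these compounds.

Compound 1 `FC(F)(F)c1ccc(C2=NN(C(=S)Nc3ccccc3)C(c3ccc4c(c3)OCCO4)C2)cc1` gives 97500 nM in a functional assay on HT-29 cells (Homo sapiens) for antiproliferative activity, read by MTT assay, with a stated time of 48 h; on this read-out lower numbers stand for stronger inhibition of growth and higher numbers for weaker inhibition of growth. Compound 2 `S=C(Nc1ccccc1)N1N=C(c2cccc(Cl)c2)CC1c1ccc2c(c1)OCCO2` reaches only the limit of > 200000 nM in this assay. The step of an at least 2.0-fold higher number from compound 1 to compound 2 (0.31 log units; beyond the scatter) is therefore known only as a bound, because one of the two values sits at the limit of > 200000 nM in this assay, at which 1 of the 2 values shown sits. Compound 3 `S=C(Nc1ccccc1)N1N=C(c2ccc(Cl)c(Cl)c2)CC1c1ccc2c(c1)OCCO2` differs from compound 2 by chloro in place of hydrogen on an aromatic carbon. For the measured compounds named here, no measured step covers such an addition, and the one step seen runs toward weaker growth inhibition. Compound 3 is expected to stay weak, with an estimated step of a number no higher from compound 2 to compound 3 (the limit leaves the size open) not beyond the scatter. Compound 3 is estimated at 200000 nM, within 80000 nM to 500000 nM.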

Compound 3, concentration for 50% growth inhibition: 95300 nM
Estimate against measurement, compound 3: 2.1-fold (0.32 log units) above, and the stated range covers the measured number.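

Here an at least 2.0-fold lower number from compound 2 to compound 3 (0.32 log units; beyond the scatter) in this assay comes with chloro in place of hydrogen ortho to a chloro group, so this position does respond to substitution, and the one addition seen runs toward stronger growth inhibition. With a 1.0-fold lower number from compound 1 to compound 3 (0.01 log units; within the scatter) for the change to 3,4-dichlorophenyl from 4-(trifluoromethyl)phenyl, these two groups do not separate here. On these data alone, the full size of the chloro step stays unknown because compound 2 stands at a limit, not a number: the limit of > 200000 nM in this assay, at which 1 of the 3 values shown sits.

Open, as far as these compounds go, is how 4-chlorophenyl alone would read, and whether an amine or a carboxylic acid on this carbon would move growth inhibition at all.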